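Methyl for methoxy on the hydroxybenzamide of compound 1

The compounds below may be only part of what the source reports. "The series", "measured", "known", "first", "only" and "open" are said of these compounds alone.

Notes on three anilides of the same nitrile-bearing aniline, all tested in a functional assay on KG-1 cells (Homo sapiens) for cytotoxicity, read by luminescence and CellTiter-Glo, with a stated time of 3 days; on this read-out lower numbers stand for stronger inhibition and higher numbers for weaker inhibition.

Compound 1 `COc1ccc(O)c(C(=O)Nc2ccc(C#N)cc2)c1` gives only a limit in this assay, > 10000 nM, and so stands at the limit of > 10000 nM in this assay, at which 2 of the 3 values shown sit, the weak end of the values seen in this set. Compound 2 `Cc1ccc(C(=O)Nc2ccc(C#N)cc2)c(O)c1` gives 2560 nM in this assay, a measured number. Compound 3 `N#Cc1ccc(NC(=O)c2ccc[nH]c2=O)cc1` also gives only a limit in this assay, > 10000 nM.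

Compound 4 `Cc1ccc(O)c(C(=O)Nc2ccc(C#N)cc2)c1` has not yet been tested. It differs from compound 1 by methyl in place of methoxy on an aromatic carbon. For the measured compounds named here, since compound 1 gives only a limit, no measured step starting from it is available. The direction of the change can only be guessed from compound 2, whose measured value 2560 nM shows that a methyl-bearing ring of this type can reach a measured number in this assay.

The step from compound 1 to compound 4 is expected to be an at least 1.6-fold lower number from compound 1 to compound 4 (0.22 log units; that floor lies within the scatter), toward somewhat stronger inhibition, but it may well stay within the scatter or return another limit. Compound 4 is estimated at 6000 nM in this assay, with a range from 2000 nM to 20000 nM.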

Compound 4, half-maximal inhibitory concentration: 3370 nM
Beside the measured number, compound 4's estimate is 1.8-fold (0.25 log units) above it, and the stated range covers the measured number.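

Methyl in place of methoxy on this aromatic carbon, para to a hydroxy group, gives this position a measured number in this assay. Compound 1 gives > 10000 nM, which is a limit of the assay and not a number. The change therefore gives an at least 2.9-fold lower number from compound 1 to compound 4 (0.47 log units; beyond the scatter), and this is only a floor, with the true size unreadable because compound 1 sits at that limit: the limit of > 10000 nM in this assay, at which 2 of the 4 values shown sit.

The compounds shown leave open whether the methyl itself matters or only the loss of the methoxy, a question on which an ethyl group, a chlorine atom or an amine at this place would bear. Also open, on these data alone, is whether the same exchange would give a step of similar size on a different core.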